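Notes on a small aromatase series: fluoro for trifluoromethoxy

The source may report more compounds than this note shows. Statements on the series, on what has been measured and on what is new or still open speak of the compounds shown alone.

Three compounds of the shared core have numbers in an assay on isolated protein for inhibition of Aromatase (Homo sapiens), tested at 1 uM; on this read-out higher numbers stand for more inhibition at the one concentration tested (going by the name of the read-out) and lower numbers for less inhibition. Compound 1 `CC(C)CC1n2cncc2CN(Cc2ccc(OC(F)(F)F)cc2)S1(=O)=O` gives 13%. Compound 2 `C[C@@H](c1ccc(Cl)cc1)N1Cc2cncn2C(CC2(C)COC2)S1(=O)=O` gives 35%, and compound 3 `CC(C)CC1n2cncc2CN(C2CC2)S1(=O)=O` gives 9%. On these three numbers compound 1 stands second highest; its nearest neighbour is compound 3, whose number lies within the scatter of it, so no order between compound 1 and compound 3 can be read. Compound 2 lies beyond the scatter above compound 1, the one clear gap in the set.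

Compound 4 `CC(C)CC1n2cncc2CN(Cc2ccc(F)cc2)S1(=O)=O` has not yet been measured. It differs from compound 1 in a single place: fluoro in place of trifluoromethoxy on an aromatic carbon. Within the data shown here, no measured pair in the set shows this change, so the size of its step is not known from a measured pair. Both compound 1 and compound 3 sit low in this assay, and nothing in the set points to a large movement in either direction. The expected step is small, a number 1 percentage points lower from compound 1 to compound 4 (within the scatter), most likely within the scatter. Compound 4 is therefore estimated at 12%, with a range from 3% to 25%, to be checked once the measurement is in hand.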

Compound 4, a percentage reported as inhibition, at one concentration (the size of the read-out at that concentration, not a potency): 39%
The estimate for compound 4 lay 27 percentage points below the measured number; the measured number lies above the stated range.
By their numbers in this assay, from the lowest: compounds 3 and 1 (each within the scatter of the next); then compounds 2 and 4 (each within the scatter of the next).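

In this assay, among these compounds, the first measured pair at this position shows that fluoro in place of trifluoromethoxy, on an aromatic carbon para to a large group, gives a number 26 percentage points higher from compound 1 to compound 4 (beyond the scatter) with the rest of compound 1 unchanged. The position is therefore not silent in this read-out, and here the group with 1 heavy atom carries the higher number, against 5 heavy atoms for the group that leaves. No measurement at hand bears on the cause of this step.

Going by these compounds, whether a methoxy group, a nitrile or plain hydrogen on the same aromatic carbon would fall nearer compound 1 or nearer compound 4 stays open, and with it whether the number follows the heavy-atom count of the group at all. Also open, on these data alone, is whether a step of this size carries over when another part of the shared core changes, as it rests on this single pair.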